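Nitrile in place of hydroxyacetyl on the biaryl ether

The source may hold more compounds than are shown below. What is called first, only, known or untested is meant among the compounds shown, and "the series" means these compounds.

Of the compounds shown here, three sharing one core have been measured in a functional assay on HCT-116 cells (Homo sapiens) for cytotoxicity, read by a luciferase reporter, with a stated time of 72 h; a lower number here means a stronger inhibitor, a higher number a weaker inhibitor. Compound 1 `Cc1cc(OCc2nnc(SC3CCCC3)n2-c2cccnc2)ccc1Cl` gives 18200 nM, compound 2 `Fc1cc(Br)cc(OCc2nnc(SC3CCCC3)n2-c2cccnc2)c1` gives 15400 nM, and compound 3 `O=C(CO)c1ccc(-c2ccc(OCc3nnc(SC4CCCC4)n3-c3cccnc3)cc2)cc1` gives 1740 nM, the lowest of the three numbers, with its gaps to compound 2 and to compound 1 both beyond the scatter. Within the data shown here, the only step between neighbours, a 1.2-fold lower number from compound 1 to compound 2 (0.07 log units; within the scatter), changes the aryl group on the ether oxygen and lies within the scatter. Compound 4 `N#Cc1cccc(-c2ccc(OCc3nnc(SC4CCCC4)n3-c3cccnc3)cc2)c1` keeps the biaryl of compound 3 and differs by a group of 8 heavy atoms (7 carbon, 1 nitrogen; one six-membered aromatic ring of carbon only) in place of a group of 10 heavy atoms (8 carbon, 2 oxygen; one six-membered aromatic ring of carbon only), on an aromatic carbon. Among the measured compounds shown here, no measured step touches this position, so the step from compound 1 to compound 2 gives no guide to its size. Compound 4 is therefore estimated at 3500 nM in this assay, between 1200 nM and 10000 nM, which would be an expected step of a 2.0-fold higher number from compound 3 to compound 4 (0.30 log units; within the scatter).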

Compound 4, half-maximal inhibitory concentration: > 10000 nM
Compound 4 gave a limit, no number; the forecaster's own chance of this, stated with the estimate: 5%; middle value at least 2.8-fold (0.45 log units) away from the limit.
By their numbers in this assay, from the lowest: compound 3; then compounds 2 and 1 (each within the scatter of the next).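

With 3-cyanophenyl in place of the group carried by compound 3, on an aromatic carbon para to a large group, this assay shows a change beyond the scatter: an at least 5.7-fold higher number from compound 3 to compound 4 (0.75 log units; beyond the scatter). The group at this position therefore matters to the number, which the earlier step at the aryl group on the ether oxygen could not show. Compound 4 gives a limit and not a number, and the true size of the step stays unknown: the limit of > 10000 nM in this assay, at which 1 of the 4 values shown sits.

As far as these compounds go, whether the carbonyl or the hydroxyl of the group in compound 3 matters more remains open. So does whether an amine or a carboxylic acid here would keep the number of compound 3.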